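The compounds below may be only part of what the source reports. "The series", "measured", "known", "first", "only" and "open" are said of these compounds alone.

Compound 1 `CC(=O)N1CCC(C(=O)N2CCC(N3CCN(C(=O)c4cc(-c5ccc(C)cc5)nc(-c5ccc(C)cc5)c4)CC3)CC2)CC1` anchors the series: in a functional assay on HepG2 cells (Homo sapiens) for inhibition, read by scintillation counting, with a stated time of 2 h (a lower number here means a stronger inhibitor, a higher number a weaker inhibitor), compound 1 gives 343 nM. Compound 2 `CCNC(=O)Nc1sc2ccccc2c1C(=O)N1CCN(C2CCN(C(=O)CC(C)C)CC2)CC1` keeps the same flexible linker but carries a different core; for compound 2 the entry in this assay reads "not determined" (no result reported), so compound 2 stands at no number and gives no reference for its own core. Compound 3 `CCNC(=O)Nc1sc2ccccc2c1C(=O)N1CCN(C2CCN(C(=O)OC3CCCCC3)CC2)CC1` is compound 2 with cyclohexyloxy in place of isobutyl on a carbonyl carbon. For the measured compounds named here, no measured step of this kind exists, so no direction is assigned; any shift in this assay is expected to be small, not beyond the scatter. Compound 3 is estimated at 300 nM, within a range of 50 nM to 2000 nM.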

Compound 3, half-maximal inhibitory concentration: 635 nM
For compound 3 the middle estimate is 2.1-fold (0.33 log units) below the measured one; measured number inside the range.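

In this assay, for the compounds shown here, compound 2 has no number, so no step to compound 3 can be read. Going by these compounds, what replacing isobutyl with cyclohexyloxy does to potency stays open, and no supporting data bear on the result.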